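The compounds below may be only part of what the source reports. "The series", "measured", "known", "first", "only" and "open" are said of these compounds alone.

Three compounds measured in a functional assay on HCT-116 cells (Homo sapiens) for cytotoxicity, read by MTT assay, with a stated time of 48 h; a lower number here means a stronger inhibitor, a higher number a weaker inhibitor:

Compound 1 `COc1ccc(NC(=O)c2cn(-c3ccccc3)nc2-c2ccc(OC)cc2)cc1` gives 1520 nM.
Compound 2 `CCOc1ccc(NC(=O)c2cn(-c3ccccc3)nc2-c2ccc(OC)cc2)cc1` gives 970 nM.
Compound 3 `COc1ccc(NC(=O)c2cn(-c3ccccc3)nc2-c2ccc(Cl)cc2)cc1` gives 1330 nM.

Compound 1 and compound 2 differ by methyl in place of hydrogen on a saturated chain carbon bound to an oxygen on an aromatic ring. This single change brought a 1.6-fold lower number from compound 1 to compound 2 (0.20 log units; within the scatter). Compound 1 and compound 3 differ in their cores by chloro in place of methoxy on an aromatic carbon, which brought a 1.1-fold lower number from compound 1 to compound 3 (0.06 log units; within the scatter).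

Compound 4 `CCOc1ccc(NC(=O)c2cn(-c3ccccc3)nc2-c2ccc(Cl)cc2)cc1` has not been measured. It stands to compound 3 as compound 2 stands to compound 1: the difference is methyl in place of hydrogen on a saturated chain carbon bound to an oxygen on an aromatic ring, at the same place in both pairs, so it is the same change made on the core of compound 3 instead of the core of compound 1.

For the measured compounds named here, the step expected from compound 3 to compound 4 in this assay is a 1.6-fold lower number from compound 3 to compound 4 (0.19 log units; within the scatter), resting on the one earlier example, a 1.6-fold lower number from compound 1 to compound 2 (0.20 log units; within the scatter), with the pair 1 and 2 being the only guide. Compound 4 is therefore estimated at 850 nM, most likely between 450 nM and 1700 nM.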

Compound 4, half-maximal inhibitory concentration: 420 nM
Beside the measured number, compound 4's estimate is 2.0-fold (0.31 log units) above it; the measured number lies below the stated range.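

In this assay, methoxy to ethoxy on the core of compound 3 brought a 3.2-fold lower number from compound 3 to compound 4 (0.50 log units; beyond the scatter), and this step does not differ firmly from the same change on the core of compound 1: the same change on two cores in this assay, a 1.6-fold lower number (0.20 log units; within the scatter) from compound 1 to compound 2 and a 3.2-fold lower number (0.50 log units; beyond the scatter) from compound 3 to compound 4, 2.0-fold (0.31 log units) apart, within the scatter of two such steps. Chloro in place of methoxy on an aromatic carbon, made with ethoxy present, brought a 2.3-fold lower number from compound 2 to compound 4 (0.36 log units; beyond the scatter), and this step also stays close to its earlier counterpart: the same change on two cores in this assay, a 1.1-fold lower number (0.06 log units; within the scatter) from compound 1 to compound 3 and a 2.3-fold lower number (0.36 log units; beyond the scatter) from compound 2 to compound 4, 2.0-fold (0.31 log units) apart, within the scatter of two such steps. So these pairs give no firm sign that either change depends on the core, but with one pair per core they cannot show that the changes are truly independent, or that this would hold on other cores.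

The compounds shown leave open whether a longer chain, such as propoxy, would lower the number further than ethoxy does. They also leave open how an amine or a carboxylic acid would compare in place of chloro.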